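A 4-Cyanophenyl Group Replaces 2-Methylphenyl on the Triazole-Free Account

The source may report more compounds than this note shows. Statements on the series, on what has been measured and on what is new or still open speak of the compounds shown alone.

PLACEHOLDER

Sorry, please disregard the lines above; the piece is below.

From 2-Methylphenyl to 4-Cyanophenyl

In a functional assay on MKN-45 cells (Homo sapiens) for inhibition, read by CCK-8 assay, with a stated time of 24 h (a lower number here means a stronger inhibitor, a higher number a weaker inhibitor), compound 1 `Cc1ccccc1-n1cc(-c2ccc(C=C3C(=O)Nc4ccc(F)cc43)cc2)nn1` gives 7210 nM. Within the data shown here, the only other measured compound, compound 2 `Cc1cccc(-n2cc(-c3ccc(/C=C4\C(=O)Nc5ccc(F)cc54)cc3)nn2)c1`, gives 6810 nM, so the two values lie within the scatter of each other and compound 1 stands level with its sole neighbour on the scale. Compound 3 `N#Cc1ccc(-n2cc(-c3ccc(C=C4C(=O)Nc5ccc(F)cc54)cc3)nn2)cc1` has not yet been measured. It keeps the shared core of compound 1 and carries 4-cyanophenyl in place of 2-methylphenyl on an aromatic nitrogen. The entering group brings a nitrile to a site where the leaving group has none. Among the measured compounds shown here, no measured pair differs in one place alone, so the data give no direct size for such a swap. For the measured compounds named here, the close agreement of compound 1 at 7210 nM and compound 2 at 6810 nM offers the only guide, and it argues against expecting a large move. A small step toward a lower number is therefore expected in this assay, possibly no larger than the scatter. The estimated change is a 1.6-fold lower number from compound 1 to compound 3 (0.20 log units; within the scatter). For compound 3 the expected value is 4500 nM, with an estimated range of 1500 nM to 12000 nM.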

Compound 3, half-maximal inhibitory concentration: > 20000 nM
Compound 3 ended at the assay's limit; the forecaster's own chance of this, stated with the estimate: 5%; at least 4.4-fold (0.64 log units) between middle value and limit.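

Replacing 2-methylphenyl with 4-cyanophenyl on the aromatic nitrogen gives, in this assay, an at least 2.7-fold higher number from compound 1 to compound 3 (0.44 log units; beyond the scatter), and compound 3 is a weaker inhibitor than compound 1. This is the first step in one place among the compounds shown, and it shows that the group at this position can change the read-out beyond the scatter, with the change here running toward weaker inhibition. The value of compound 3 is a limit and not a number, so only the smallest possible size of the step is known, and how much weaker compound 3 is remains undetermined: the limit of > 20000 nM in this assay, at which 1 of the 3 values shown sits.

The compounds shown do not separate the part played by the entering nitrile from that played by the leaving methyl group, and they give no cause for the step. From the compounds shown here alone, a plain phenyl, 4-methylphenyl or 4-methoxyphenyl group at this position could help to separate these parts, and how any of them would read in this assay remains open.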